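The source may hold more compounds than are shown below. What is called first, only, known or untested is meant among the compounds shown, and "the series" means these compounds.

Working notes on the series. Among the measured compounds shown here, compound 1 `COc1cc(N(Cc2nc3ccccc3[nH]2)S(=O)(=O)c2ccccc2Cl)cc(OC)c1OC` is the only member with a plain number: in a functional assay on PC-3 cells (Homo sapiens) for inhibition, read by MTT assay, with a stated time of 48 h (on this read-out lower numbers stand for stronger inhibition and higher numbers for weaker inhibition), compound 1 gives 34500 nM. Compound 2 `COc1cc(N(Cc2nc3ccccc3[nH]2)C(=O)c2cccc(Cl)c2)cc(OC)c1OC` carries a (3-chlorophenyl)carbonyl on the nitrogen in place of the (2-chlorophenyl)sulfonyl. In this assay compound 2 gives only a limit, > 50000 nM, so merely a lower bound is known for it. For the measured compounds named here, the single measured step, an at least 1.4-fold higher number from compound 1 to compound 2 (0.16 log units; that floor lies within the scatter), is capped by the limit of > 50000 nM in this assay, at which 1 of the 2 values shown sits, and cannot be read beyond that. Compound 3 `COc1cc(N(Cc2nc3ccccc3[nH]2)C(=O)c2ccc(C)cc2)cc(OC)c1OC` differs from compound 2 by 4-methylphenyl in place of 3-chlorophenyl on a carbonyl carbon. Going by the values given here, no measured step touches an exchange on the carbonyl-bound ring; the one step in hand concerns the group on the nitrogen as a whole and is itself limited. The expected step is a step that the limit leaves unreadable from compound 2 to compound 3, that is, nothing beyond the scatter, and a limit-only reading remains the most likely outcome. Compound 3 is therefore estimated in this assay at 60000 nM, within 20000 nM to 200000 nM.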

Compound 3, half-maximal inhibitory concentration: 42000 nM
Compound 3: the middle estimate sits 1.4-fold (0.15 log units) above what was measured; low and high end bracket the measured number.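

In this assay compound 3 gives 42000 nM, a plain number for a member with a carbonyl on the nitrogen, which compound 2 did not provide. The exchange of the whole group on the nitrogen reads as a 1.2-fold higher number from compound 1 to compound 3 (0.09 log units; within the scatter), so a (2-chlorophenyl)sulfonyl and a (4-methylphenyl)carbonyl cannot be told apart on this read-out. The exchange on the carbonyl carbon reads as an at least 1.1-fold lower number from compound 2 to compound 3 (0.07 log units; that floor lies within the scatter), and it remains only a floor because the value of compound 2 is a limit: the limit of > 50000 nM in this assay, at which 1 of the 3 values shown sits.

On these data alone, whether the ring on the carbonyl carbon influences the read-out at all stays open, since only 3-chlorophenyl and 4-methylphenyl appear there. A phenyl ring bearing an amine or a carboxylic acid, or a cyclohexyl group on that carbonyl, lies outside the compounds shown.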